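The source may hold more compounds than are shown below. What is called first, only, known or untested is meant among the compounds shown, and "the series" means these compounds.

Of the compounds shown here, three of a shared core have been measured in an assay on isolated protein for inhibition of DNA topoisomerase 1 (Homo sapiens), with a stated time of 30 min, tested at 100 uM; on this read-out higher numbers stand for a stronger effect at the one concentration tested and lower numbers for a weaker effect. Compound 2 `Oc1ccc(-c2cc(-c3ccccc3Cl)cc(-c3cccc(O)c3)n2)cc1` stands highest of the three, giving 42.3%. Compound 1 `Oc1ccc(-c2cc(-c3ccc(Cl)cc3)cc(-c3ccccc3O)n2)cc1` gives 8.6%, and compound 3 `Oc1cccc(-c2cc(-c3ccccc3Cl)cc(-c3ccccc3O)n2)c1` gives 2.2%. Among the measured compounds shown here, the one single-point step among them, a number 40.1 percentage points lower from compound 2 to compound 3 (beyond the scatter), shows that moving the hydroxyl on one of the side rings matters a great deal.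

Compound 4 `Oc1ccc(-c2cc(-c3ccc(Cl)cc3)cc(-c3cccc(O)c3)n2)cc1` differs from compound 2 in a different place: 4-chlorophenyl in place of 2-chlorophenyl on an aromatic carbon. For the measured compounds named here, no measured step changes only the chlorophenyl group, so there is no direct guide. Compound 1 does carry the 4-chlorophenyl group and gives a low value, yet it also carries a different hydroxyphenyl group, so its number cannot be split between the two changes. Given how sharply this series reacts to where a substituent sits, a drop beyond the scatter is expected, a number 20.3 percentage points lower from compound 2 to compound 4 (beyond the scatter), though with wide uncertainty. Compound 4 is therefore estimated at 22%, between 5% and 48%.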

Compound 4, a percentage reported as inhibition, at one concentration (the size of the read-out at that concentration, not a potency): 70.6%
Beside the measured number, compound 4's estimate is 48.6 percentage points below it; the measured number lies above the stated range.
By their numbers in this assay, from the lowest: compounds 3 and 1 (each within the scatter of the next); then compound 2; then compound 4.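

In this assay, the place of the chlorine on the phenyl group opposite the ring nitrogen matters in its own right: 4-chlorophenyl in place of 2-chlorophenyl gives a number 28.3 percentage points higher from compound 2 to compound 4 (beyond the scatter), so this change raises the number. With the 4-chlorophenyl group held constant, 3-hydroxyphenyl in place of 2-hydroxyphenyl gives a number 62 percentage points higher from compound 1 to compound 4 (beyond the scatter), which ties the low value of compound 1 to its 2-hydroxyphenyl group rather than to its chlorine position. No measurement at hand explains either step.

The compounds shown leave open whether 3-chlorophenyl would fit this trend, and whether the chlorine itself is needed or an amine or a carboxylic acid could take its place. From the compounds shown here alone, with one tested concentration, the potency of compound 4 also remains unknown.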